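Two methyls in place of methoxy on the benzyl ring

The source may report more compounds than this note shows. Statements on the series, on what has been measured and on what is new or still open speak of the compounds shown alone.

Compound 1 `COc1cc(N)c(Cl)cc1NC(=O)C1CCN(Cc2cccc(C)c2)CC1` gives 2.4 mg/kg in a functional assay on the whole organism for antagonist activity, with Mus musculus as the target; a higher number here means that more compound is needed for the effect, a lower number that less compound is needed.
Compound 2 `COc1cc(N)c(Cl)cc1NC(=O)C1CCN(Cc2ccccc2F)CC1` reaches only a limit, > 4 mg/kg, in this assay.
Compound 3 `COc1cccc(CN2CCC(C(=O)Nc3cc(Cl)c(N)cc3OC)CC2)c1` also reaches only a limit, > 4 mg/kg, in this assay.

Compound 3 therefore stands at the limit where two of the three values sit (the limit of > 4 mg/kg in this assay, at which 2 of the 3 values shown sit), and no number is known for it. Compound 4 `COc1cc(N)c(Cl)cc1NC(=O)C1CCN(Cc2ccc(C)c(C)c2)CC1` differs from it in one place: 3,4-dimethylphenyl in place of 3-methoxyphenyl on a saturated chain carbon bound to an amine nitrogen in a ring. Among the measured compounds shown here, the one measured step that bears on this is an at least 1.6-fold higher number from compound 1 to compound 3 (0.22 log units; that floor lies within the scatter), which runs the other way, methoxy replacing methyl, and raised the number. Reversing that, with a second methyl added, is expected to lower the number, though its size cannot be read from a limit. The expected step in this assay is an at least 1.3-fold lower number from compound 3 to compound 4 (0.12 log units; that floor lies within the scatter). Compound 4 is estimated at 3 mg/kg, between 1.5 mg/kg and 8 mg/kg.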

Compound 4, dose for half-maximal effect: > 8 mg/kg
Compound 4 ended at the assay's limit; the forecaster's own chance of this, stated with the estimate: 40%; at least 2.6-fold (0.42 log units) between middle value and limit.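

In this assay, adding a second methyl to the benzyl ring gives an at least 3.3-fold higher number from compound 1 to compound 4 (0.52 log units; beyond the scatter). Among the compounds shown here, this is the first step that can be read as beyond the scatter, and it shows that a change made only of methyl, with no fluorine or oxygen involved, can raise the dose needed at this place. The value of compound 4 is a limit: the limit of > 8 mg/kg in this assay, at which 1 of the 4 values shown sits.

The steps linking compound 4 to compounds 2 and 3 cannot be read, with limits at both ends. From the compounds shown here alone, whether a 3-ethylbenzyl or a 3-aminobenzyl group at this place would keep a measurable dose stays open.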